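Adding an amino group to compound 3

The compounds below may be only part of what the source reports. "The series", "measured", "known", "first", "only" and "open" are said of these compounds alone.

In a functional assay on COR-L23 cells (Homo sapiens) for antiproliferative activity, read by CellTiter-Glo, with a stated time of 72 h (on this read-out lower numbers stand for stronger inhibition and higher numbers for weaker inhibition), compound 3 `CCC(=O)N[C@@H](C)c1ccc(NC(=O)N2CC(c3cccnc3)C2)cc1` gives 120 nM, within the scatter of compound 1 `C[C@H](NC(=O)c1ncccn1)c1ccc(NC(=O)N2CC(c3cccnc3)C2)cc1` at 130 nM, while compound 2 `C[C@H](NC(=O)C1CCOCC1)c1ccc(NC(=O)N2CC(c3cccnc3)C2)cc1` gives a lower 58 nM. Compound 4 `CCC(=O)N[C@@H](C)c1ccc(NC(=O)N2CC(c3ccc(N)nc3)C2)cc1` replaces pyridin-3-yl with 6-aminopyridin-3-yl, placing amino in place of hydrogen next to the ring nitrogen: amino in place of hydrogen on an aromatic carbon. The measured steps, a 2.2-fold lower number from compound 1 to compound 2 (0.35 log units; beyond the scatter), a 1.1-fold lower number from compound 1 to compound 3 (0.03 log units; within the scatter) and a 2.1-fold higher number from compound 2 to compound 3 (0.32 log units; beyond the scatter), all change the group on a carbonyl carbon. None alters the pyridin-3-yl group, so they show only how large changes elsewhere were and give no direction. The expected change, with wide uncertainty, is no step beyond the scatter: a 1.3-fold higher number from compound 3 to compound 4 (0.10 log units; within the scatter). Compound 4 is estimated at 150 nM, with an expected range from 35 nM to 650 nM.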

Compound 4, half-maximal inhibitory concentration: 120 nM
Compound 4: middle estimate off by 1.3-fold (0.10 log units), on the high side; the measured number falls inside the stated range.
By their numbers in this assay, from the lowest: compound 2; then compounds 3, 4 and 1 (each within the scatter of the next).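

Amino in place of hydrogen on an aromatic carbon is the first change shown on the pyridin-3-yl group rather than on the group at the carbonyl carbon, and in this assay it gives no change at the digits printed from compound 3 to compound 4 (within the scatter). This position therefore accepts 6-aminopyridin-3-yl with the propanamide side unchanged. Nothing available explains this outcome.

As far as these compounds go, whether amino behaves the same with oxan-4-yl on the carbonyl carbon, as in compound 2, remains open. So does the outcome for a methoxy group or a dimethylamino group at this position.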